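Aryl sulfonamide replacement in a bradykinin antagonist series

This account rests on a few compounds, and the source may have more. Where it says the series, first, only, none or still open, it means among the compounds named here.

Measured so far:
- compound 1, `COc1ccc(S(=O)(=O)N(C)CCOCC(=O)N(C)Cc2ccc(C3=NCCN3)cc2)c(C)c1`: 5.5 nM
- compound 2, `COc1cc(C)c(S(=O)(=O)N(C)CCOCC(=O)N2CCC(C3CCN(C)CC3)CC2)c(C)c1`: 0.7 nM
- compound 3, `COc1cc(C)c(S(=O)(=O)N(C)CCOCC(=O)N2CCN(C3CCN(C4CC4)CC3)CC2)c(C)c1`: 0.8 nM

All three were measured in an assay on HEK293 cells for displacement of a labelled ligand from B1 bradykinin receptor (Homo sapiens), read by scintillation counting; on this read-out higher numbers stand for weaker inhibition and lower numbers for stronger inhibition. Compound 1 stands at the highest of the three numbers. Compound 3 gives the nearest lower number, and compound 2 the furthest, and both gaps to compound 1 lie beyond the scatter. Going by the values given here, compound 2 and compound 3 differ from compound 1 both in the aryl part of the sulfonamide and in the amide side, so neither pair isolates a single change, and no step between measured compounds is available.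

The next compound, compound 4, is `CN(Cc1ccc(C2=NCCN2)cc1)C(=O)COCCN(C)S(=O)(=O)c1c(F)cccc1F`. It differs from compound 1 in one place: 2,6-difluorophenyl in place of 4-methoxy-2-methylphenyl on a sulfonyl sulfur. The aryl part that leaves carries the only hydrogen-bond acceptor of that group; the one that enters carries none. Among the compounds with values here, no measured pair shows what this change does in this assay, so the expectation rests on the position of compound 1 alone and on the general weight of the change. The expected step is a 2.2-fold higher number from compound 1 to compound 4 (0.34 log units; beyond the scatter), a modest move toward a higher number, with a wide range allowed either way. Compound 4 is estimated at 12 nM, between 3 nM and 50 nM.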

Compound 4, inhibition constant: 142 nM
For compound 4 the middle estimate is 12-fold (1.07 log units) below the measured one, outside the stated range (above it).
By their numbers in this assay, from the lowest: compounds 2 and 3 (each within the scatter of the next); then compound 1; then compound 4.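

In this assay, going by these compounds alone, this is the only step that changes one place, and it shows that the sulfonyl aryl position is far from indifferent to the group it carries: a 26-fold higher number from compound 1 to compound 4 (1.41 log units; beyond the scatter) on going to 2,6-difluorophenyl in place of 4-methoxy-2-methylphenyl. The step therefore marks this aryl group as a strong handle on the number in this series, although it rests on a single pair. The change removes the only hydrogen-bond acceptor of the group and exchanges methoxy and methyl for two fluorines at once, and nothing shown here gives a reason for the size of the step or ties it to any one of these parts.

Open, going by these compounds, is which part of the exchange carries the step: a 4-methoxyphenyl, a 2-methylphenyl or a 4-methoxy-2,6-difluorophenyl group on the same sulfonyl sulfur would separate the methoxy from the methyl and the fluorines. Also open, on these data alone, is whether the step would hold on the different amide sides of compound 2 and compound 3, for which no single-place comparison is available.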